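Aryl group on the ring nitrogen: three limits so far

The source may hold more compounds than are shown below. What is called first, only, known or untested is meant among the compounds shown, and "the series" means these compounds.

Measured so far, in a functional assay on HCT-116 cells (Homo sapiens) for antiproliferative activity, read by MTT assay, with a stated time of 48 h; on this read-out lower numbers stand for stronger inhibition and higher numbers for weaker inhibition:
compound 1 `N#CC1=C(N)Oc2c(c3nc4ccccc4nc3c3ccccc23)C12C(=O)N(Cc1cnnn1-c1ccc(F)cc1)c1ccccc12` gives > 50000 nM, a limit.
compound 2 `N#CC1=C(N)Oc2c(c3nc4ccccc4nc3c3ccccc23)C12C(=O)N(Cc1cnnn1-c1cccc(Cl)c1)c1ccccc12` gives > 50000 nM, a limit.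
compound 3 `N#CC1=C(N)Oc2c(c3nc4ccccc4nc3c3ccccc23)C12C(=O)N(Cc1cnnn1-c1ccc(Br)cc1)c1ccccc12` gives > 50000 nM, a limit.

Compound 2 sits at the limit of > 50000 nM in this assay, at which 3 of the 3 values shown sit, so no order among the three can be read. The steps a step that the two limits leave unreadable from compound 1 to compound 2, a step that the two limits leave unreadable from compound 1 to compound 3 and a step that the two limits leave unreadable from compound 2 to compound 3 bear on the aryl group at the ring nitrogen, and all three are unreadable. Compound 4 `COc1ccc(-n2nncc2CN2C(=O)C3(C(C#N)=C(N)Oc4c3c3nc5ccccc5nc3c3ccccc43)c3ccccc32)cc1` differs from compound 2 by 4-methoxyphenyl in place of 3-chlorophenyl on an aromatic nitrogen. Within the data shown here, no measured step gives a size or a direction for such a change; the three limits only suggest that compound 4 stays in the same region. For compound 4 the value in this assay is estimated at 50000 nM, between 15000 nM and 150000 nM, most likely again a limit. The expected step of a number no higher from compound 2 to compound 4 (the limit leaves the size open) is none beyond the scatter.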

Compound 4, half-maximal inhibitory concentration: > 50000 nM
Compound 4 gave a limit, no number; the forecaster's own chance of this, stated with the estimate: 80%; the middle value lies on the limit itself.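

No step among compound 1, compound 2, compound 3 and compound 4 can be read, since all four rest on the same limit: the limit of > 50000 nM in this assay, at which 4 of the 4 values shown sit.
The compounds shown leave open whether any aryl group on this ring nitrogen gives a measurable value, and how these four would rank.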